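A Hydroxymethyl Group Replaces the Acid on a Shared Core

The source may report more compounds than this note shows. Statements on the series, on what has been measured and on what is new or still open speak of the compounds shown alone.

Of the compounds shown here, three built on one shared core have been tested in a functional assay on cells (Platelet, Homo sapiens) for inhibition; a lower number here means a stronger inhibitor, a higher number a weaker inhibitor. Compound 1 `CCOC(=O)c1ccc(-c2nn(C)c3ccccc23)cc1` gives > 10000 nM in this assay, which is a limit of the assay and not a number. Compound 2 `CCOC(=O)c1ccc(-c2nn(Cc3ccccc3F)c3ccccc23)cc1` gives > 10000 nM, again a limit. Compound 3 `O=C(O)c1ccc(-c2nn(Cc3ccccc3)c3ccccc23)cc1` gives > 10000 nM, also a limit. Among the compounds with values here, the only single-point step among them, a step that the two limits leave unreadable from compound 1 to compound 2, has a size that cannot be read because both of its ends sit at the limit of > 10000 nM in this assay, at which 3 of the 3 values shown sit. Compound 3 therefore stands exactly where the other two stand, at the limit of > 10000 nM in this assay, at which 3 of the 3 values shown sit, and nothing in the numbers separates the three.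

Compound 4 `OCc1ccc(-c2nn(Cc3ccccc3)c3ccccc23)cc1` differs from compound 3 in one place: hydroxymethyl in place of carboxy on an aromatic carbon. No measured step involves a carboxy or a hydroxymethyl group, so none of the steps shown bears on this change, and its size and direction cannot be drawn from them. Given that compound 3 sits at the limit of > 10000 nM in this assay, at which 3 of the 3 values shown sit, compound 4 is expected to give a similar reading, with the expected step being a number no higher from compound 3 to compound 4 (the limit leaves the size open). The estimate for compound 4 in this assay is 10000 nM, with a likely range from 3000 nM to 30000 nM, and a fair chance that only a limit is reported.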

Compound 4, half-maximal inhibitory concentration: > 10000 nM
Compound 4 was reported as a limit (the forecaster's own chance of this, stated with the estimate: 70%); the middle value lies on the limit itself.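

The change from carboxy to hydroxymethyl between compound 3 and compound 4 gives no step that can be read, since the results for both compounds are limits and not numbers: the limit of > 10000 nM in this assay, at which 4 of the 4 values shown sit.

The compounds shown leave open whether any group on the shared core gives a readable inhibition in this assay, and how large the effect of each change is.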